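This account rests on a few compounds, and the source may have more. Where it says the series, first, only, none or still open, it means among the compounds named here.

Three compounds sharing one core were assessed in a functional assay on MGC-803 cells (Homo sapiens) for antiproliferative activity, read by CCK-8 assay, with a stated time of 72 h, tested at 2 uM; a higher number here means a stronger effect of the compound at the concentration tested, a lower number a weaker effect. Compound 1 `Nc1ccccc1NC(=O)c1ccc(CSC(=S)N2CCN(c3ccc(Cl)cc3)CC2)cc1` gives 15% in this assay, the lowest of the three numbers. Compound 2 `Nc1ccccc1NC(=O)c1ccc(CSC(=S)N2CCc3ccccc32)cc1` gives 44%, a number beyond the scatter above that of compound 1. Compound 3 `CCN(Cc1ccncc1)C(=S)SCc1ccc(C(=O)Nc2ccccc2N)cc1` gives 71.6%, the highest of the three and beyond the scatter above both others. Within the data shown here, the one single-point step among the measured compounds, a number 27.6 percentage points higher from compound 2 to compound 3 (beyond the scatter), arises when ethyl((pyridin-4-yl)methyl)amino replaces 2,3-dihydro-1H-indol-1-yl on the thiocarbonyl carbon.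

Compound 4 `Nc1ccccc1NC(=O)c1ccc(CSC(=S)N2CCN(Cc3ccncc3)CC2)cc1` is not yet measured. It differs from compound 1 as follows: (pyridin-4-yl)methyl in place of 4-chlorophenyl on an amine nitrogen in a ring. The change brings in the same (pyridin-4-yl)methyl group that entered from compound 2 to compound 3, though there it arrived on the thiocarbonyl carbon and here it arrives on an amine nitrogen in a ring in place of 4-chlorophenyl. Among the measured compounds shown here, that step is the only measured guide and it was modest, so a rise of similar size, at most, is expected, with wide uncertainty because the site of the change differs. Compound 4 is therefore expected to give 40% in this assay, within a range of 20% to 65%. The expected step is a number 25 percentage points higher from compound 1 to compound 4 (beyond the scatter).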

Compound 4, a percentage reported as inhibition, at one concentration (the size of the read-out at that concentration, not a potency): 18.4%
Estimate against measurement, compound 4: 21.6 percentage points above; measured number outside the range, below it.
By their numbers in this assay, from the lowest: compounds 1 and 4 (each within the scatter of the next); then compound 2; then compound 3.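

In this assay, putting (pyridin-4-yl)methyl in place of 4-chlorophenyl on the amine nitrogen in the six-membered non-aromatic ring with 2 nitrogen gives a number 3.4 percentage points higher from compound 1 to compound 4 (within the scatter), so at this position the two groups leave the read-out unchanged within the scatter, although the entering group brings an aromatic ring with 1 hetero atom and a hydrogen-bond acceptor and the leaving group brings chlorine. The (pyridin-4-yl)methyl group therefore does not go with a higher number wherever it appears: it was part of the change that gave a number 27.6 percentage points higher from compound 2 to compound 3 (beyond the scatter) on the thiocarbonyl carbon, whereas compound 4 goes against any such general pattern. Nothing measured here offers an explanation for this difference between the two sites.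

Still open, going by these compounds, is whether a quite different group on the same ring nitrogen, such as a methyl, an acetyl or a 2-hydroxyethyl chain, would move the number away from those of compound 1 and compound 4. Also open, on these data alone, is what the ethyl group contributes in compound 3, where a propyl chain or a plain hydrogen on that nitrogen would speak to the question.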